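Removing the Methyl Group: an Expected Small Shift

The source may hold more compounds than are shown below. What is called first, only, known or untested is meant among the compounds shown, and "the series" means these compounds.

Of the compounds shown here, three sharing one core have been tested in a functional assay, read by spectrophotometry, with a stated time of 15 min, tested at 80 ug/mL; on this read-out higher numbers stand for a stronger effect at the one concentration tested and lower numbers for a weaker effect. Compound 1 `Clc1ccc(-c2csc(N/N=C/c3cccs3)n2)cc1` gives 96.6%, compound 2 `Cc1ccc(-c2csc(N/N=C/c3ccc(Cl)cc3Cl)n2)cc1` gives 90.7%, and compound 3 `Cc1ccc(-c2csc(N/N=C/c3cccs3)n2)cc1` gives 97.8%. The value of compound 2 lies within the usual scatter of the values of compound 1 and of compound 3, so no order among the three can be read from these numbers. For the measured compounds named here, the only measured step between compounds differing in a single place is a number 1.2 percentage points higher from compound 1 to compound 3 (within the scatter), and it stays within the scatter.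

Compound 4 `Clc1ccc(/C=N/Nc2nc(-c3ccccc3)cs2)c(Cl)c1` differs from compound 2 in one place: hydrogen in place of methyl on an aromatic carbon. The change sits on the same aromatic carbon that the measured step altered, and because a number 1.2 percentage points higher from compound 1 to compound 3 (within the scatter) produced no shift beyond the scatter, no shift beyond the scatter is expected here either. The expected step is a number 0.7 percentage points lower from compound 2 to compound 4 (within the scatter). Compound 4 is therefore estimated to give 90%, with a range from 80% to 98%.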

Compound 4, a percentage reported as inhibition, at one concentration (the size of the read-out at that concentration, not a potency): 92.6%
For compound 4 the middle estimate is 2.6 percentage points below the measured one, and the stated range covers the measured number.
By their numbers in this assay, from the lowest: compounds 2, 4, 1 and 3 (each within the scatter of the next).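

In this assay the change from 4-methylphenyl to phenyl gives a number 1.9 percentage points higher from compound 2 to compound 4 (within the scatter) and so shows that this aromatic carbon, para to a large group, can carry a plain hydrogen with no shift beyond the scatter. The earlier step only exchanged one substituent for another, whereas this one removes the substituent altogether, and it does so in a compound that differs elsewhere from compound 1 and compound 3. Nothing at hand explains the result or tells what these single-concentration numbers mean for potency.

From the compounds shown here alone, it remains open whether an amine, a carboxylic acid or a longer chain on this carbon would also stay within the scatter. Going by these compounds, it is also open whether hydrogen here would behave the same way with the rest of the structure shared by compound 1 and compound 3.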